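This account rests on a few compounds, and the source may have more. Where it says the series, first, only, none or still open, it means among the compounds named here.

Measured so far in a functional assay on the whole organism (strain C57Bl/6) for inhibition, with Mus musculus as the target, with a stated time of 180 min, at 48 degrees C; on this read-out lower numbers stand for an effect already at smaller amounts and higher numbers for an effect only at larger amounts of compound:

Compound 1 `COc1ccc(Cn2c(=O)nc(NCCNC(=N)N)n(Cc3ccc(I)cc3)c2=O)cc1`: compound 1 gives 0.039 nM.
Compound 2 `COc1ccc(Cn2c(=O)nc(NCCNC(=N)N)n(Cc3ccc(Br)cc3)c2=O)cc1`: compound 2 gives 0.0043 nM.
Compound 3 `COc1ccc(Cn2c(=O)nc(NCCNC(=N)N)n(Cc3ccc(C)cc3)c2=O)cc1`: compound 3 gives 0.0045 nM.

Compound 3 stands second of the three numbers, but its nearest neighbour is compound 2, with a 1.0-fold higher number from compound 2 to compound 3 (0.02 log units; within the scatter), so the two cannot be told apart. The only large movements in the set come from the iodo compound: a 9.1-fold lower number from compound 1 to compound 2 (0.96 log units; beyond the scatter) and an 8.7-fold lower number from compound 1 to compound 3 (0.94 log units; beyond the scatter). All three measured steps concern the substituent on one benzyl ring; the other benzyl ring, carrying methoxy, is unchanged throughout.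

Compound 4 `Cc1ccc(Cn2c(NCCNC(=N)N)nc(=O)n(Cc3ccc(C(F)(F)F)cc3)c2=O)cc1` is the next case. The change from compound 3 to compound 4 is trifluoromethyl in place of methoxy on an aromatic carbon. Going by the values given here, no measured step touches this ring, so nothing in the set speaks directly to the size of the effect. The measured steps show that the change from compound 2 to compound 3 stays within the scatter, while the two steps from compound 1 lie beyond it. By analogy, a modest shift in either direction is possible, and no step beyond the scatter is firmly expected in this assay.

Compound 4 is therefore estimated at 0.006 nM, with a range from 0.0015 nM to 0.025 nM. This estimate means a step of a 1.3-fold higher number from compound 3 to compound 4 (0.12 log units; within the scatter), expected to lie within the scatter.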

Compound 4, half-maximal effective concentration: 0.000033 nM
Compound 4: the middle estimate sits 180-fold (2.26 log units) above what was measured; measured number below the stated range.
By their numbers in this assay, from the lowest: compound 4; then compounds 2 and 3 (each within the scatter of the next); then compound 1.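

In this assay, the 4-methoxybenzyl group, held constant across compound 1, compound 2 and compound 3, turns out to be a position where the number can move strongly: trifluoromethyl in place of methoxy gives a 140-fold lower number from compound 3 to compound 4 (2.13 log units; beyond the scatter). Going by these compounds alone, this step is clearly larger than either step seen on the other benzyl ring, a 9.1-fold lower number from compound 1 to compound 2 (0.96 log units; beyond the scatter) and an 8.7-fold lower number from compound 1 to compound 3 (0.94 log units; beyond the scatter), so the earlier compounds gave no measure of how much this position can change the read-out. No measurement at hand bears on why this replacement has so large an effect.

A single pair cannot separate the loss of methoxy from the gain of trifluoromethyl, and a hydrogen, chloro, nitrile, carboxylic acid or amine on the same aromatic carbon would help show which of the two drives the step. Within the data shown here, it also remains open whether the step carries over when the other benzyl ring bears bromo or iodo in place of methyl, as the only comparison here has methyl on that ring.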